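From fluoro to methyl: a solubility estimate for compound 4

This account rests on a few compounds, and the source may have more. Where it says the series, first, only, none or still open, it means among the compounds named here.

In a physicochemical assay for solubility, read by HPLC, with a stated time of 4 h, at pH 7 (a higher number here means a more soluble compound, a lower number a less soluble compound), compound 1 `C[C@]1(COc2ccc(N3CCN(S(=O)(=O)c4ccc(F)cc4)CC3)cc2)Cn2cc([N+](=O)[O-])nc2O1` gives 8.33 ug/mL as the lower of the two numbers obtained so far. Compound 2 `C[C@]1(COc2ccc(S(=O)(=O)N3CCOCC3)cc2)Cn2cc([N+](=O)[O-])nc2O1` gives 20 ug/mL and the gap between these two numbers lies beyond the usual scatter. Compound 3 `Cc1ccc(NC(=O)Nc2ccc(OC[C@@]3(C)Cn4cc([N+](=O)[O-])nc4O3)cc2)cc1` stands at < 1 ug/mL which is a limit of the assay and not a number. Compound 4 `Cc1ccc(S(=O)(=O)N2CCN(c3ccc(OC[C@@]4(C)Cn5cc([N+](=O)[O-])nc5O4)cc3)CC2)cc1` differs from compound 1 methyl in place of fluoro on an aromatic carbon by carrying methyl in place of fluoro on an aromatic carbon, para to a large group. Among the measured compounds shown here, no measured step shows this change in this assay so the expectation rests on compound 1 at 8.33 ug/mL and foresees no step beyond the scatter, with at most a slight fall. The estimated move is a 1.4-fold lower number from compound 1 to compound 4 (0.14 log units; within the scatter) and stays within the scatter. For compound 4 the expected value is 6 ug/mL with an estimated range from 2 ug/mL to 14 ug/mL in this measurement.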

Compound 4, solubility: < 1 ug/mL
Compound 4: no number, only a limit (the forecaster's own chance of this, stated with the estimate: 10%); middle value at least 6.0-fold (0.77 log units) away from the limit.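

Methyl in place of fluoro, on an aromatic carbon para to a large group, is the first single change that can be read in this assay and gives an at least 8.3-fold lower number from compound 1 to compound 4 (0.92 log units; beyond the scatter) in this series. The exchange is one heavy atom for one heavy atom, with no hydrogen-bond donor or acceptor on either side, and yet the step lies beyond the scatter. Compound 4 reads < 1 ug/mL, which is a limit and not a number, so the step has only a lower bound: the limit of < 1 ug/mL in this assay, at which 2 of the 4 values shown sit.

The compounds shown leave open how far compound 4 lies under that limit. They also leave open whether an amine or a carboxylic acid on that aromatic carbon would bring the reading back above it.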